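Swapping methyl for isopropyl on the shared core

A few compounds are considered here, and "the series" means these few. Any claim that something is new, unique, unknown or untested is made for them only; others in the source may bear on it.

Compound 1 `CCC1(C)CCOC1=O`: 259 mg/kg
Compound 2 `CC(C)C1(C)CCOC1=O`: 198 mg/kg

In a functional assay on the whole organism for inhibition, with Mus musculus as the target (on this read-out higher numbers stand for an effect only at larger amounts of compound and lower numbers for an effect already at smaller amounts), compound 2 gives 198 mg/kg, which lies within the scatter of compound 1 at 259 mg/kg. Compound 3 `CC(C)C1(C(C)C)CCOC1=O` carries isopropyl in place of methyl on a saturated ring carbon. Among the measured compounds shown here, only one measured step bears on this change: a 1.3-fold lower number from compound 1 to compound 2 (0.12 log units; within the scatter), for methyl in place of hydrogen on a saturated chain carbon. That step stayed within the scatter, but it sits elsewhere and is a single example. No shift beyond the scatter is therefore expected in this assay, and no direction can be given. The expected change is a 1.1-fold lower number from compound 2 to compound 3 (0.04 log units; within the scatter). Compound 3 is estimated at 180 mg/kg, with an expected range of 85 mg/kg to 340 mg/kg.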

Compound 3, dose for half-maximal effect: 137 mg/kg
Compound 3: the middle estimate sits 1.3-fold (0.12 log units) above what was measured; measured number inside the range.
By their numbers in this assay, from the lowest: compounds 3, 2 and 1 (each within the scatter of the next).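

On the saturated ring carbon, two ring bonds from the ring oxygen, isopropyl in place of methyl gives a 1.4-fold lower number from compound 2 to compound 3 (0.16 log units; within the scatter) in this assay as the read-out. This position therefore takes three heavy atoms instead of one with no shift beyond the scatter, and the earlier step, which lay on a chain carbon, could not show this. Nothing available explains the result. Going by these compounds, whether an amine, a carboxylic acid or a longer chain on this ring carbon would move the number beyond the scatter remains open.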